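Paw edema inhibition: dropping the trifluoromethyl group

The source may report more compounds than this note shows. Statements on the series, on what has been measured and on what is new or still open speak of the compounds shown alone.

compound 1 `O=C(O)c1ccccc1[S+]([O-])c1cccc(C(F)(F)F)c1`: 4%
compound 2 `O=C(O)c1ccccc1S(=O)(=O)c1ccccc1`: 15%

Two compounds have been run in a functional assay on the whole organism (strain Holtzmann) for inhibition, with Rattus norvegicus as the target, read by paw edema, with a stated time of 2.5 h, at a dose of 50 mg/kg by the oral route; a lower number here means less inhibition, a higher number more inhibition at the dose given (going by the name of the read-out). For the measured compounds named here, compound 1 stands lowest of the two; compound 2 sits higher by a gap beyond the scatter, but the two differ in more than one place and no single step joins them. Compound 3 `O=C(O)c1ccccc1[S+]([O-])c1ccccc1` differs from compound 1 as follows: hydrogen in place of trifluoromethyl on an aromatic carbon. Going by the values given here, no measured pair isolates this change, so in this assay a small step is expected, likely within the scatter, if anything upward. Compound 3 is expected to give 10%, between 0% and 25%. This corresponds to an expected step of a number 6 percentage points higher from compound 1 to compound 3 (within the scatter).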

Compound 3, a percentage reported as inhibition, in the whole organism at one dose (the size of the read-out at that dose, not a potency): 19%
Compound 3: middle estimate off by 9 percentage points, on the low side; low and high end bracket the measured number.
By their numbers in this assay, from the lowest: compound 1; then compounds 2 and 3 (each within the scatter of the next).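

Hydrogen in place of trifluoromethyl on an aromatic carbon gives a number 15 percentage points higher from compound 1 to compound 3 (beyond the scatter) in this assay and is the first single-place step in the series. This position therefore responds to substitution, with the trifluoromethyl compound lower than its hydrogen partner at the dose given. No data bear on the reason for this step.

Open, going by these compounds, is whether a chlorine atom or a methoxy group at this place would sit nearer compound 1 or compound 3. Also open, on these data alone, is whether a one-carbon methyl group would behave like trifluoromethyl here.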